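Propargyl to 4-fluorobenzyl in a weakly active series

A few compounds are considered here, and "the series" means these few. Any claim that something is new, unique, unknown or untested is made for them only; others in the source may bear on it.

For the measured compounds named here, in a functional assay on HeLa cells (Homo sapiens) for inhibition, read by WST assay, with stated times of 72 h and 2 h (a lower number here means a stronger inhibitor, a higher number a weaker inhibitor), compound 1 (`C#CCOC(c1cccs1)c1cc2ccccc2nc1Cl`) gives 34700 nM, the only number available so far. Compound 2 (`Oc1ccc(-c2cc(COC(c3cccs3)c3cc4ccccc4nc3Cl)on2)cc1`) is reported as "not active" (no number reported), without a number, so no step can be read from the pair. Compound 3 (`Fc1ccc(COC(c2cccs2)c2cc3ccccc3nc2Cl)cc1`) has not yet been measured. It carries 4-fluorophenyl in place of ethynyl on a saturated chain carbon bound to an oxygen on a saturated carbon, which also reads as propargyl to 4-fluorobenzyl: 4-fluorophenyl in place of ethynyl on a saturated chain carbon bound to an oxygen on a saturated carbon. Going by the values given here, with no measured step to draw on, the expected 1.0-fold higher number from compound 1 to compound 3 (0.00 log units; within the scatter) in this assay is estimated to stay within the usual scatter, with no firm direction. A result without a number also remains possible, as seen for compound 2 at "not active" (no number reported). For compound 3 the estimate is 35000 nM, with an expected range of 12000 nM to 90000 nM.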

Compound 3, half-maximal inhibitory concentration: 73900 nM
Compound 3: middle estimate off by 2.1-fold (0.32 log units), on the low side; the range from low to high includes it.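

For the compounds shown here, the first readable step at this position is modest but beyond the scatter: in this assay, 4-fluorophenyl in place of ethynyl on a saturated chain carbon bound to an oxygen on a saturated carbon gives a 2.1-fold higher number from compound 1 to compound 3 (0.33 log units; beyond the scatter). The larger group, with 7 heavy atoms against 2, still leaves a numerical result, as compound 3 gives 73900 nM, though both values show only weak inhibition. The data shown offer no explanation for the higher number.

Any step involving compound 2 cannot be read, as it has no number. As far as these compounds go, it remains open whether the step belongs to the aromatic ring or to its fluorine, which a plain benzyl would separate, and how an amine or a carboxylic acid at this position would read in this assay.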